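The compounds below may be only part of what the source reports. "The series", "measured", "known", "first", "only" and "open" are said of these compounds alone.

Compound 1 `CC(C)[C@H](NC(=O)c1cc(Cl)ccc1OCCNC(=O)O)C(=O)Nc1ccc([N+](=O)[O-])cc1Cl`: > 10000 nM
Compound 2 `CC(C)[C@H](NC(=O)c1cc(Cl)ccc1OCCNC(=O)OCc1ccccc1)C(=O)Nc1ccc([N+](=O)[O-])cc1Cl`: > 10000 nM
Compound 3 `CC(C)[C@H](NC(=O)c1cc(Cl)ccc1OCCCN)C(=O)Nc1ccc([N+](=O)[O-])cc1Cl`: > 10000 nM

These entries from a functional assay on MCF7 cells (Homo sapiens) for inhibition, read by MTT assay, with a stated time of 72 h (on this read-out higher numbers stand for weaker inhibition and lower numbers for stronger inhibition), are limits of the assay, not numbers. Compound 3 therefore has no exact position, and the series shows only (the limit of > 10000 nM in this assay, at which 3 of the 3 values shown sit).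

Compound 4 `CC(C)[C@H](NC(=O)c1cc(Cl)ccc1OCCCCNC(=O)OC(C)(C)C)C(=O)Nc1ccc([N+](=O)[O-])cc1Cl` differs from compound 3 by ((tert-butoxycarbonyl)amino)methyl in place of amino on a saturated chain carbon, three bonds along the chain from an oxygen on an aromatic ring. Thus ((tert-butoxycarbonyl)amino)methyl stands in place of amino on a saturated chain carbon, three bonds along the chain from an oxygen on an aromatic ring.

The closest measured changes also alter this chain end: a step that the two limits leave unreadable from compound 1 to compound 3 and a step that the two limits leave unreadable from compound 2 to compound 3. a step that the two limits leave unreadable from compound 1 to compound 2 also gives no size. With no measured shift to carry over, no direction can be expected, only no change beyond the scatter in this assay. The expected step is a step that the limit leaves unreadable from compound 3 to compound 4. For compound 4 the estimated value is 15000 nM, with an expected range of 5000 nM to 50000 nM.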

Compound 4, half-maximal inhibitory concentration: > 10000 nM
Compound 4 was reported as a limit (the forecaster's own chance of this, stated with the estimate: 85%); the middle value is on the limit's open side.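

Compound 4 gives only a limit, as do compound 1, compound 2 and compound 3, so no step among them can be read: the limit of > 10000 nM in this assay, at which 4 of the 4 values shown sit.

The compounds shown leave open whether any of these chain ends gives a measurable inhibition value.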